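The compounds below may be only part of what the source reports. "The series", "measured", "known", "first", "only" and "open" are said of these compounds alone.

For the measured compounds named here, compound 3 `O=C(CSc1snnc1-c1ccc(Cl)cc1Cl)Nc1ccccc1F` is the one compound of the three for which an ADME assay on MT4 cells (Homo sapiens) for cytotoxicity (a higher number here means that more compound is tolerated, a lower number that less compound is tolerated), returns an actual number: compound 3 gives 19500 nM. Compound 1 `Cc1ccc(NC(=O)CSc2snnc2-c2ccc(Cl)cc2Cl)c(Br)c1` sits at a limit of this assay, > 255000 nM, which is not a number. Compound 2 `Cc1ccc(NC(=O)CSc2snnc2-c2ccc(F)cc2F)c(Br)c1` likewise sits at a limit of this assay, > 273000 nM. Compound 4 `O=C(CSc1snnc1-c1ccc(F)cc1F)Nc1ccccc1F` differs from compound 3 by 2,4-difluorophenyl in place of 2,4-dichlorophenyl on an aromatic carbon. The same exchange has been made once already, but the step that the two limits leave unreadable from compound 1 to compound 2 stays hidden between the two limits (the limit of > 255000 nM in this assay, at which 1 of the 3 values shown sits, and (the limit of > 273000 nM in this assay, at which 1 of the 3 values shown sits)), so its size is not known. The other measured step, an at least 13-fold lower number from compound 1 to compound 3 (1.11 log units; beyond the scatter), concerns the group on the amide-type nitrogen and not the group changed here, so it says little about the present step. With no readable precedent, no step beyond the scatter in this assay is expected from compound 3 to compound 4, a 1.3-fold higher number from compound 3 to compound 4 (0.11 log units; within the scatter). Compound 4 is therefore estimated at 25000 nM in this assay, with a range from 8000 nM to 100000 nM.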

Compound 4, half-maximal cytotoxic concentration: 148000 nM
For compound 4 the middle estimate is 5.9-fold (0.77 log units) below the measured one; the measured number lies above the stated range.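

The exchange of 2,4-dichlorophenyl for 2,4-difluorophenyl now has a readable size in this assay: a 7.6-fold higher number from compound 3 to compound 4 (0.88 log units; beyond the scatter). This shows that the group on this aromatic carbon of the shared core can change how much compound the cells tolerate, which compound 1 and compound 2 could not show, as both sit at limits of the assay. The exchange of 2-bromo-4-methylphenyl for 2-fluorophenyl on the amide-type nitrogen also gains a second case, an at least 1.8-fold lower number from compound 2 to compound 4 (0.26 log units; that floor lies within the scatter), so that change can now be set side by side on two cores: the same change on two cores in this assay, an at least 13-fold lower number (1.11 log units; beyond the scatter) from compound 1 to compound 3 and an at least 1.8-fold lower number (0.26 log units; that floor lies within the scatter) from compound 2 to compound 4; the limit leaves it open whether they differ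

For the compounds shown here, with only one readable step, these compounds do not show why the exchange has this effect or whether it would hold on other cores. Also open, from the compounds shown here alone, is how an unsubstituted phenyl ring, or a phenyl ring bearing methoxy groups or an amine, would behave at this position.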